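Replacing 4-fluorobenzyl on the amine nitrogen of compound 1

The source may report more compounds than this note shows. Statements on the series, on what has been measured and on what is new or still open speak of the compounds shown alone.

In a toxicity assay on MDCK cells (Canis lupus familiaris) for cytotoxicity, read by crystal violet staining, with a stated time of 48 h (on this read-out higher numbers stand for lower toxicity in this test and lower numbers for higher toxicity in this test), compound 1 (`CCc1ccc2[nH]c(=O)c(CN(Cc3ccc(F)cc3)Cc3ccc(C(C)(C)C)cc3)cc2c1`) gives > 33000 nM, which is a limit and not a number. Going by the values given here, compound 2 (`CCc1ccc2[nH]c(=O)c(CN(Cc3ccc(F)cc3)Cc3cccc4ccccc34)cc2c1`) gives > 5000 nM, which is also a limit, so the series so far offers no exact value in this assay. Compound 3 (`CCc1ccc2[nH]c(=O)c(CN(Cc3ccc(C(C)(C)C)cc3)[C@H](CO)c3ccccc3)cc2c1`) differs from compound 1 at one place, with 2-hydroxy-1-phenylethyl in place of 4-fluorobenzyl on an amine nitrogen. Among the compounds with values here, the only measured step, a step that the two limits leave unreadable from compound 1 to compound 2, concerns the 4-(tert-butyl)phenyl group, which compound 3 keeps. Since a step that the two limits leave unreadable from compound 1 to compound 2 has no readable size, no shift beyond the scatter is expected in this assay, and no direction can be given. The expected step is an at least 1.1-fold lower number from compound 1 to compound 3 (0.04 log units; that floor lies within the scatter). For compound 3 the estimated value is 30000 nM, with an expected range of 10000 nM to 80000 nM.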

Compound 3, half-maximal cytotoxic concentration: > 10000 nM
Compound 3: only a limit was reported; the forecaster's own chance of this, stated with the estimate: 60%; the middle value does not contradict the limit.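

In this assay compound 1 gives > 33000 nM, a limit. Going by these compounds alone, compound 3 gives > 10000 nM, also a limit, so no step between compound 1 and compound 3 can be read. The compounds shown leave open the exact cytotoxic concentration of each compound, and the size and direction of either replacement.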